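Phenyl Analogue of a Butylphenyl Isoxazole Nucleoside

A few compounds are considered here, and "the series" means these few. Any claim that something is new, unique, unknown or untested is made for them only; others in the source may bear on it.

Measured so far:
compound 1 `CCCCc1ccc(-c2cc(-c3cn([C@H]4C[C@H](OC(C)=O)[C@@H](COC(C)=O)O4)c(=O)[nH]c3=O)on2)cc1`: 71.4%
compound 2 `CCCc1cc(-c2cn([C@H]3C[C@H](OC(C)=O)[C@@H](COC(C)=O)O3)c(=O)[nH]c2=O)on1`: 98.8%
compound 3 `CC(=O)OC[C@H]1O[C@@H](n2cc(-c3cc(-c4ccc(C(C)C)cc4)no3)c(=O)[nH]c2=O)C[C@@H]1OC(C)=O`: 80.9%

In a functional assay on HCT-15 cells (Homo sapiens) for cytotoxicity, read by sulforhodamine B assay, tested at 10 uM (a lower number here means less inhibition, a higher number more inhibition at the concentration tested (going by the name of the read-out)), compound 1 stands lowest of the three measured compounds; compound 3 lies within the scatter of it, while compound 2 lies beyond it. Compound 4 `CC(=O)OC[C@H]1O[C@@H](n2cc(-c3cc(-c4ccccc4)no3)c(=O)[nH]c2=O)C[C@@H]1OC(C)=O` differs from compound 1 by hydrogen in place of butyl on an aromatic carbon. Among the compounds with values here, the step that bears most on this change is the one from compound 1 to compound 3, a number 9.5 percentage points higher from compound 1 to compound 3 (within the scatter), where one alkyl on the same aromatic carbon replaced another without a change beyond the scatter. The larger step of a number 27.4 percentage points higher from compound 1 to compound 2 (beyond the scatter) removed the whole 4-butylphenyl and is less comparable. Compound 4 is therefore expected to show a small step, a number 6.6 percentage points higher from compound 1 to compound 4 (within the scatter), probably not beyond the scatter. The estimated value of compound 4 is 78%, in a range from 58% to 95%.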

Compound 4, a percentage reported as inhibition, at one concentration (the size of the read-out at that concentration, not a potency): 92.2%
Beside the measured number, compound 4's estimate is 14.2 percentage points below it, and the stated range covers the measured number.
By their numbers in this assay, from the lowest: compounds 1 and 3 (each within the scatter of the next); then compounds 4 and 2 (each within the scatter of the next).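

In this assay hydrogen in place of butyl gives a number 20.8 percentage points higher from compound 1 to compound 4 (beyond the scatter) and hydrogen in place of isopropyl gives a number 11.3 percentage points higher from compound 3 to compound 4 (beyond the scatter) on the same aromatic carbon, so removing the alkyl altogether counts where swapping one alkyl for the other did not. Phenyl in place of propyl gives only a number 6.6 percentage points lower from compound 2 to compound 4 (within the scatter) and so the lower numbers of compound 1 and compound 3 go with the alkyl on the ring, not with the phenyl ring alone. From the compounds shown here alone, whether methyl, fluorine or an amine on that carbon would hold the number of compound 4 stays open. Nothing available explains these steps.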